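A few compounds are considered here, and "the series" means these few. Any claim that something is new, unique, unknown or untested is made for them only; others in the source may bear on it.

Values in a functional assay on SK-OV-3 cells (Homo sapiens) for antiproliferative activity, read by MTT assay, with a stated time of 72 h; a higher number here means a weaker inhibitor, a lower number a stronger inhibitor:
- Compound 1 `O=C(CCc1cccc2c1B(O)OC2)Nc1ccccc1`: 200 nM
- Compound 2 `O=C(CCc1cccc2c1B(O)OC2)Nc1nccs1`: > 100000 nM, a limit of the assay
- Compound 3 `O=C(CCc1cccc2c1B(O)OC2)Nc1ccc(Cl)cc1`: 5000 nM

Compound 3 has the higher of the two true numbers, and a 25-fold higher number from compound 1 to compound 3 (1.40 log units; beyond the scatter). Compound 4 `O=C(CCc1cccc2c1B(O)OC2)Nc1ccc(Br)cc1` has bromo in place of chloro on an aromatic carbon, para to a large group: bromo in place of chloro on an aromatic carbon.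

The closest measured step is the large 25-fold higher number from compound 1 to compound 3 (1.40 log units; beyond the scatter), which puts chloro in place of hydrogen at that carbon. The other large step, an at least 20-fold lower number from compound 2 to compound 3 (1.30 log units; beyond the scatter), replaces the whole group on the amide-type nitrogen. Among the measured compounds shown here, no step from one halogen to another has been measured, so no shift beyond the scatter is expected in this assay, with wide uncertainty.

The expected step is no change at the digits printed from compound 3 to compound 4 (within the scatter). For compound 4 the estimate is 5000 nM, expected within 1500 nM to 17000 nM.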

Compound 4, half-maximal inhibitory concentration: 9200 nM
Compound 4: middle estimate off by 1.8-fold (0.26 log units), on the low side; the measured number falls inside the stated range.
By their numbers in this assay, from the lowest: compound 1; then compounds 3 and 4 (each within the scatter of the next). At a limit, above all of these: compound 2.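

In this assay, bromo in place of chloro at this carbon gives a 1.8-fold higher number from compound 3 to compound 4 (0.26 log units; within the scatter), so the two halogens cannot be told apart here. The large loss seen with chloro against the hydrogen of compound 1 also holds for a second halogen, with a 46-fold higher number from compound 1 to compound 4 (1.66 log units; beyond the scatter). Compound 2 stands at a limit, which the step of an at least 10-fold lower number from compound 2 to compound 4 (1.03 log units; beyond the scatter) carries: the limit of > 100000 nM in this assay, at which 1 of the 4 values shown sits.

From the compounds shown here alone, whether the loss belongs to halogens alone or to any group at this carbon stays open. A methoxy group or an amine at the same carbon would separate these two readings.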